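Shortening the Ester Chain and Cytotoxicity on HeLa Cells

A few compounds are considered here, and "the series" means these few. Any claim that something is new, unique, unknown or untested is made for them only; others in the source may bear on it.

Compound 2 `CCCCCCCCOC(=O)C(O)Cn1cnc2c(N)ncnc21` carries an octyl ester on the shared core. Within the data shown here, in a functional assay on HeLa cells (Homo sapiens) for cytotoxicity (on this read-out higher numbers stand for lower toxicity in this test and lower numbers for higher toxicity in this test), compound 2 gives 100 ug/mL, the only actual number among the three measured compounds. Compound 1 `Nc1ncnc2c1ncn2CC(O)C(=O)OCCO` gives > 400 ug/mL, which is a limit of the assay rather than a number. Compound 3 `COCCOC(=O)C(O)Cn1cnc2c(N)ncnc21` gives > 400 ug/mL, also a limit. Compound 4 `CCOC(=O)C(O)Cn1cnc2c(N)ncnc21` carries an ethyl ester; it differs from compound 2 by hydrogen in place of hexyl on a saturated chain carbon, two bonds along the chain from an oxygen next to a carbonyl group. Among the measured compounds shown here, two measured steps bear on this change: an at least 4.0-fold lower number from compound 1 to compound 2 (0.60 log units; beyond the scatter), and an at least 4.0-fold higher number from compound 2 to compound 3 (0.60 log units; beyond the scatter). Both end at the limit of > 400 ug/mL in this assay, at which 2 of the 3 values shown sit, so the shorter ester of compound 4 is expected to move upward by a 4.0-fold higher number from compound 2 to compound 4 (0.60 log units; beyond the scatter). The value for compound 4 is estimated at 400 ug/mL, with a range from 200 ug/mL to 800 ug/mL.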

Compound 4, minimum cytotoxic concentration: > 400 ug/mL
Compound 4: no number, only a limit (the forecaster's own chance of this, stated with the estimate: 70%); the middle value sits exactly at the limit.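

In this assay, the change from octyl to ethyl gives an at least 4.0-fold higher number from compound 2 to compound 4 (0.60 log units; beyond the scatter). Until now, only esters with a hydroxy or methoxy group at this place had reached the limit, and compound 4 shows that a plain ethyl ester without either group reaches it too. The steps joining compound 4 to compound 1 and compound 3 cannot be read, and the values of all three are limits: the limit of > 400 ug/mL in this assay, at which 3 of the 4 values shown sit.

The compounds shown leave open where between ethyl and octyl the number starts to fall, as a butyl ester might show. From the compounds shown here alone, a longer chain than octyl, or an amine at this place, also remains open.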